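Swapping methylsulfonyl for ethylsulfanyl on the shared core

A few compounds are considered here, and "the series" means these few. Any claim that something is new, unique, unknown or untested is made for them only; others in the source may bear on it.

Compound 1 `Cn1c(-c2ccccc2)nnc1[S+](C)[O-]`: > 100 mg/kg
Compound 2 `Cn1c(-c2ccccc2)nnc1S(C)(=O)=O`: > 200 mg/kg

Both compounds were tested in a functional assay on the whole organism for antagonist activity, with Mus musculus as the target, in the maximal electroshock model; on this read-out lower numbers stand for an effect already at smaller amounts and higher numbers for an effect only at larger amounts of compound. Compound 1 gives > 100 mg/kg, which is a limit and not a number. From the compounds shown here alone, compound 2 gives > 200 mg/kg, which is also a limit, so its exact position in this assay is unknown.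

Compound 3 `CCSc1nnc(-c2ccccc2)n1C` has not yet been measured. It differs from compound 2 by one change: ethylsulfanyl in place of methylsulfonyl on an aromatic carbon.

For the measured compounds named here, only one measured step bears on this change, and it lies on the same aromatic carbon: a step that the two limits leave unreadable from compound 1 to compound 2. That step has no readable size, so it offers no size to carry over, and ethylsulfanyl itself has no measurement here. Any forecast is therefore loose. A move towards a lower number is expected because the value of compound 2 is the limit > 200 mg/kg, and a number can only appear on the lower side of it. The estimated change is an at least 3.3-fold lower number from compound 2 to compound 3 (0.52 log units; beyond the scatter). For compound 3 the expected value is 60 mg/kg. The estimated range runs from 20 mg/kg to 200 mg/kg.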

Compound 3, dose for half-maximal effect: > 200 mg/kg
Compound 3: a limit, no number; the forecaster's own chance of this, stated with the estimate: 35%; middle value at least 3.3-fold (0.52 log units) away from the limit.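

In this assay compound 3 gives > 200 mg/kg, which is a limit and not a number. Compound 1 and compound 2 also give limits, so no step between any two of these compounds can be read. The compounds shown leave open whether ethylsulfanyl, methylsulfonyl or the group on compound 1 differ at all on this read-out.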